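The source may report more compounds than this note shows. Statements on the series, on what has been measured and on what is new or still open speak of the compounds shown alone.

Three compounds measured in a functional assay (mitochondria, heart) with Bos taurus as the target (a higher number here means a weaker inhibitor, a lower number a stronger inhibitor), frame this account. Compound 1 `CCCCCCCCCCn1c(N)c(N)c(=O)[nH]c1=O` gives 280 nM in this assay. Compound 2 `CCCCCCCCCCCCNc1c(N)n(Cc2ccccc2)c(=O)[nH]c1=O` gives 670 nM in this assay. Compound 3 `CCCCCCCCn1c(=O)[nH]c(=O)c2[nH]c(O)nc21` gives 28000 nM in this assay, the highest of the three numbers; its nearest neighbour is compound 2 and its furthest is compound 1, and both gaps lie beyond the scatter of the method, so compound 3 is the weakest inhibitor of the three.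

Compound 4 `CCCCCCCCCCCCn1c(=O)[nH]c(=O)c2[nH]c(O)nc21` has not yet been measured. It differs from compound 3 in a single place: butyl in place of hydrogen on a saturated chain carbon, eight bonds along the chain from an aromatic nitrogen. Among the measured compounds shown here, compounds 1 and 2 carry longer chains than compound 3 and lower numbers, but each also differs from compound 3 in its core, so no measured pair shows what the chain extension alone does. On that slim basis the step is expected to go toward a lower number: the estimated step of a 2.3-fold lower number from compound 3 to compound 4 (0.37 log units; beyond the scatter) would be moderate, beyond the scatter yet far short of closing the gap to compound 2. Compound 4 is therefore expected to give about 12000 nM in this assay, with a likely range from 3000 nM to 40000 nM.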

Compound 4, half-maximal inhibitory concentration in the Bos taurus assay: 1600 nM
The estimate for compound 4 lay 7.5-fold (0.88 log units) above the measured number; the whole stated range lies above it.
By their numbers in the Bos taurus assay, from the lowest: compound 1; then compound 2; then compound 4; then compound 3.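

In the Bos taurus assay, butyl in place of hydrogen on a saturated chain carbon, eight bonds along the chain from an aromatic nitrogen, gives an 18-fold lower number from compound 3 to compound 4 (1.24 log units; beyond the scatter), a large step. Among the compounds shown here, this is the first pair in the account that shares a core and differs in one place, so it shows that the chain extension alone makes compound 4 a clearly stronger inhibitor than compound 3, with no change to the core needed. In a physicochemical assay for lipophilicity (on this read-out lower numbers stand for lower lipophilicity and higher numbers for higher lipophilicity), compound 3 gives 1.1 and compound 4 gives 2.9. In the physicochemical assay the same change also comes with a large rise in lipophilicity, so the gain in inhibition and the rise in lipophilicity travel together in this pair: the measured partition coefficient of compound 3, 1.1, and of compound 4, 2.9, a number 1.80 log units higher (beyond the scatter)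

A single pair cannot tell whether the inhibition follows lipophilicity itself or the length of the chain as such, and compounds 1 and 2 differ from compound 4 in too many places to help. On these data alone, it also remains open whether a longer chain would carry the trend further, and whether a chain ending in a carboxylic acid or an amine would keep the inhibition seen with compound 4.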